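Extending the Amine Side Chain of a Nitroimidazole Sulfonamide

A few compounds are considered here, and "the series" means these few. Any claim that something is new, unique, unknown or untested is made for them only; others in the source may bear on it.

Measured so far in a physicochemical assay for solubility, read by HPLC; a lower number here means a less soluble compound, a higher number a more soluble compound:
compound 1 `COCCCNS(=O)(=O)CCn1c([N+](=O)[O-])cnc1C` gives 17000000 nM
compound 2 `Cc1ncc([N+](=O)[O-])n1CCS(=O)(=O)NCCO` gives > 49300000 nM
compound 3 `Cc1ncc([N+](=O)[O-])n1CCS(=O)(=O)NCCN(C)C` gives 46800000 nM

The value for compound 2 is a limit of this assay rather than a number, as noted in the limit of > 49300000 nM in this assay, at which 1 of the 3 values shown sits. Among the two numbers that are not limits, compound 3 stands highest, with compound 1 nearest at a 2.8-fold higher number from compound 1 to compound 3 (0.44 log units; beyond the scatter). The swap from compound 1 to compound 2 read an at least 2.9-fold higher number from compound 1 to compound 2 (0.46 log units; beyond the scatter), while between compound 2 and compound 3 the difference was an at least 1.0-fold lower number from compound 2 to compound 3 (0.02 log units; that floor lies within the scatter).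

Compound 4 `Cc1ncc([N+](=O)[O-])n1CCS(=O)(=O)NCCCN(C)C` is not yet measured. It differs from compound 3 by (dimethylamino)methyl in place of dimethylamino on a saturated chain carbon, two bonds along the chain from a sulfonamide nitrogen. Among the compounds with values here, none of the measured steps changes the length of this chain; all three exchange the group at the end of it. The closest guide is the step from compound 2 to compound 3, which stayed within the scatter, and the exchange from compound 1 to compound 3, which was modest. For compound 4 in this assay, a step of a 1.2-fold lower number from compound 3 to compound 4 (0.07 log units; within the scatter) is therefore expected, not beyond the scatter. Compound 4 is estimated at 40000000 nM, within 20000000 nM to 60000000 nM.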

Compound 4, solubility: > 53800000 nM
Compound 4: no number, only a limit (the forecaster's own chance of this, stated with the estimate: 15%); middle value at least 1.3-fold (0.12 log units) from the limit.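

Compound 4 gives no number in this assay, only a limit: the limit of > 53800000 nM in this assay, at which 1 of the 4 values shown sits. Within the data shown here, this is the first change of chain length at this position, from 2-(dimethylamino)ethyl to 3-(dimethylamino)propyl, and it reads an at least 1.1-fold higher number from compound 3 to compound 4 (0.06 log units; that floor lies within the scatter), so the limit leaves open whether the added carbon moves the solubility reading beyond the scatter at all. Among these compounds, at the same chain length, dimethylamino in place of methoxy gives an at least 3.1-fold higher number from compound 1 to compound 4 (0.50 log units; beyond the scatter), which is the first comparison of these two end groups that does not also change the length of the chain.

From the compounds shown here alone, compound 2 and compound 4 both stand at limits, so the step between them cannot be read, and how far compound 4 lies past its limit stays unknown. Also open, going by these compounds, is how a longer chain, or a carboxylic acid at the end of this chain, would read in this assay.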